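This account rests on a few compounds, and the source may have more. Where it says the series, first, only, none or still open, it means among the compounds named here.

Compound 2 `CC(C(=O)NCc1ccc(C(F)(F)F)nc1N1CCC(C)(C)CC1)c1ccc(NS(C)(=O)=O)c(F)c1` gives the lowest of the two numbers measured in a functional assay on CHO-K1 cells for antagonist activity at transient receptor potential cation channel subfamily V member 1 (Homo sapiens), read by FLIPR (a higher number here means a weaker inhibitor, a lower number a stronger inhibitor), at 0.3 nM; its nearest neighbour is compound 1 `Cc1ccc(Nc2nc(C(F)(F)F)ccc2CNC(=O)C(C)c2ccc(NS(C)(=O)=O)c(F)c2)cc1C`, which in this assay gives 39.3 nM. Going by the values given here, the only measured step, a 130-fold lower number from compound 1 to compound 2 (2.12 log units; beyond the scatter), swapped an aromatic amine for a saturated ring and does not reproduce the change now considered. Compound 3 `CCCCOC1CCN(c2nc(C(F)(F)F)ccc2CNC(=O)C(C)c2ccc(NS(C)(=O)=O)c(F)c2)CC1` differs from compound 2 by a group of 11 heavy atoms (9 carbon, 1 nitrogen, 1 oxygen; one six-membered non-aromatic ring with 1 hetero atom) in place of a group of 8 heavy atoms (7 carbon, 1 nitrogen; one six-membered non-aromatic ring with 1 hetero atom), on an aromatic carbon. Among the compounds with values here, with no comparable step measured, the saturated ring is kept and only its substitution changes, so the expected step of a 2.7-fold higher number from compound 2 to compound 3 (0.43 log units; beyond the scatter) is small. Compound 3 is estimated at 0.8 nM, within 0.15 nM to 4 nM.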

Compound 3, inhibition constant: 3.5 nM
The estimate for compound 3 lay 4.4-fold (0.64 log units) below the measured number, and the stated range covers the measured number.
By their numbers in this assay, from the lowest: compound 2; then compound 3; then compound 1.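

The step of a 12-fold higher number from compound 2 to compound 3 (1.07 log units; beyond the scatter) shows that in this assay changing only the substitution on the saturated ring, on the aromatic carbon next to the ring nitrogen, matters a great deal. The step of an 11-fold lower number from compound 1 to compound 3 (1.05 log units; beyond the scatter) shows that compound 3 still keeps much of the gain over the aromatic amine of compound 1. No measurement at hand accounts for either step.

The compounds shown leave open whether the butoxy chain itself sets this loss. A shorter methoxy group, or an amine on the saturated ring, might land nearer compound 2 or nearer compound 3.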